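The source may report more compounds than this note shows. Statements on the series, on what has been measured and on what is new or still open speak of the compounds shown alone.

Measured compounds:
compound 1 `O=S(=O)(CC1=NCCS1)C1C(c2ccccc2)=NN(c2ccccc2)C1c1ccccc1`, in a functional assay, read by Griess assay, with a stated time of 150 min, tested at 100 ug/mL (on this read-out lower numbers stand for a weaker effect and higher numbers for a stronger effect at the one concentration tested), compound 1 is reported as "not active" (no number reported), with no number given;
compound 2 `COc1ccc(C2=NOC(c3ccc(C)cc3)C2S(=O)(=O)CC2=NCCO2)cc1`, in this assay compound 2 gives 71.3%;
compound 3 `COc1ccc(C2=NOC(c3ccc(C)cc3)C2S(=O)(=O)CC2=NCCS2)cc1`, in this assay compound 3 gives 59.6%.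

Compounds 2 and 3 share one core and differ in a single place: a group of 5 heavy atoms (3 carbon, 1 nitrogen, 1 oxygen; one five-membered non-aromatic ring with 2 hetero atoms) in place of a group of 5 heavy atoms (3 carbon, 1 nitrogen, 1 sulfur; one five-membered non-aromatic ring with 2 hetero atoms), on a saturated chain carbon bound to a sulfonyl sulfur. That change is accompanied by a step of a number 11.7 percentage points higher from compound 3 to compound 2 (beyond the scatter).

Compound 4 `O=S(=O)(CC1=NCCO1)C1C(c2ccccc2)=NN(c2ccccc2)C1c1ccccc1` is built on the core of compound 1 rather than that of compound 3; the difference between the two cores is not broken down here. Compound 4 stands to compound 1 as compound 2 stands to compound 3, the same kind of change at the same place: a group of 5 heavy atoms (3 carbon, 1 nitrogen, 1 oxygen; one five-membered non-aromatic ring with 2 hetero atoms) in place of a group of 5 heavy atoms (3 carbon, 1 nitrogen, 1 sulfur; one five-membered non-aromatic ring with 2 hetero atoms), on a saturated chain carbon bound to a sulfonyl sulfur.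

Because compound 1 is reported as "not active" (no number reported) without a number, there is no starting value on which the step could be laid. Within the data shown here, the one measured step of this change, a number 11.7 percentage points higher from compound 3 to compound 2 (beyond the scatter), is modest, and a modest rise from an inactive compound is expected to leave compound 4 weak. In this assay compound 4 is therefore expected to give about 15%, estimated to lie between 0% and 40%.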

Compound 4, a percentage reported as activity, at one concentration (the size of the read-out at that concentration, not a potency): 57.9%
Compound 4: the middle estimate sits 42.9 percentage points below what was measured; measured number above the stated range.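

No new step can be read from compound 1 to compound 4 in this assay, since compound 1 is reported as "not active" (no number reported) and has no number to start from. Nothing shown here accounts for this result. The compounds shown leave open how large this change is on the core of compound 1, and whether it matches a number 11.7 percentage points higher from compound 3 to compound 2 (beyond the scatter).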